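From benzyl to 3,4-difluorobenzyl in compound 2

The source may report more compounds than this note shows. Statements on the series, on what has been measured and on what is new or still open speak of the compounds shown alone.

Among the measured compounds shown here, in an ADME assay on the whole organism (strain Sprague-Dawley) for pharmacokinetics, with Rattus norvegicus as the target, using cassette dosing (a lower number here means slower removal, a higher number faster removal of the compound), compound 2 `O[C@]1(Cc2cc(-c3cn[nH]c3)on2)CC[C@H](Cc2ccccc2)CC1` gives 56.5 mL/min/kg, the highest of the three numbers measured so far. Compound 1 `O=c1[nH]c2ccc(-c3cc(C[C@]4(O)CC[C@@H](Cc5ccccc5)CC4)no3)cc2o1` gives 12.1 mL/min/kg, and compound 3 `O[C@]1(Cc2cc(-c3cn[nH]c3)on2)CC[C@H](Cc2ccc(OC(F)(F)F)cc2)CC1` gives 6.2 mL/min/kg. Compound 4 `O[C@]1(Cc2cc(-c3cn[nH]c3)on2)CC[C@H](Cc2ccc(F)c(F)c2)CC1` remains unmeasured and differs from compound 2 by 3,4-difluorophenyl in place of phenyl on a saturated chain carbon bound to a saturated ring carbon, which also reads as benzyl to 3,4-difluorobenzyl. The closest measured change is trifluoromethoxy in place of hydrogen on an aromatic carbon, seen in a 9.1-fold lower number from compound 2 to compound 3 (0.96 log units; beyond the scatter). The other measured step, a 4.7-fold higher number from compound 1 to compound 2 (0.67 log units; beyond the scatter), concerns a different group and bears little on this change. The same direction is expected here, with a smaller size, as a 2.6-fold lower number from compound 2 to compound 4 (0.41 log units; beyond the scatter). Compound 4 is estimated at 22 mL/min/kg, with an expected range of 9 mL/min/kg to 45 mL/min/kg.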

Compound 4, clearance: 15.2 mL/min/kg
For compound 4 the middle estimate is 1.4-fold (0.16 log units) above the measured one; the range from low to high includes it.
By their numbers in this assay, from the lowest: compounds 3, 1 and 4 (each within the scatter of the next, the first and the last beyond it); then compound 2.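

In this assay, 3,4-difluorophenyl in place of phenyl gives a 3.7-fold lower number from compound 2 to compound 4 (0.57 log units; beyond the scatter), so the fall seen with trifluoromethoxy on this aromatic ring is not confined to that one substituent. Compound 4, at 15.2 mL/min/kg, still stands above compound 3, at 6.2 mL/min/kg, by more than the scatter. Nothing shown gives a reason for either fall. From the compounds shown here alone, whether a nitrile, a methoxy or an amine on this ring would lower the number as well stays open. So does whether 3,4-difluorophenyl would have the same effect on the core of compound 1.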